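This account rests on a few compounds, and the source may have more. Where it says the series, first, only, none or still open, it means among the compounds named here.

Measured compounds in a functional assay on SMA cells (Homo sapiens) for inhibition, read by MTT assay, with a stated time of 72 h; on this read-out higher numbers stand for weaker inhibition of growth and lower numbers for stronger inhibition of growth:
- compound 1 `N#C/C(=C\c1ccco1)C(=O)NCc1ccc(Cl)c(Cl)c1`: 38000 nM
- compound 2 `COc1ccc(CNC(=O)/C(C#N)=C/c2cc(Br)co2)cc1`: a limit of the assay, > 100000 nM
- compound 3 `COc1ccc(CNC(=O)/C(C#N)=C/c2ccc3ccccc3c2)cc1`: 43000 nM

Compound 1 and compound 3 give numbers that sit within the scatter of each other, so neither can be ranked against the other. The value of compound 2 is only a limit, as noted in the limit of > 100000 nM in this assay, at which 1 of the 3 values shown sits, and gives no number to compare. No pair of these compounds differs in a single place, so no measured step exists.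

Compound 4 `N#C/C(=C\c1ccc(Cl)cc1)C(=O)NCc1ccc(Cl)c(Cl)c1` differs from compound 1 by 4-chlorophenyl in place of furan-2-yl on a double-bonded chain carbon bound to a double-bonded chain carbon. Nothing measured here tracks that exchange, so the expected step of a 1.3-fold lower number from compound 1 to compound 4 (0.10 log units; within the scatter) is set near zero, within the scatter and with no clear direction. Compound 4 is therefore estimated at 30000 nM, with a range from 10000 nM to 100000 nM.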

Compound 4, concentration for 50% growth inhibition: 33000 nM
Compound 4: the middle estimate sits 1.1-fold (0.04 log units) below what was measured; the measured number falls inside the stated range.
By their numbers in this assay, from the lowest: compounds 4, 1 and 3 (each within the scatter of the next). At a limit, above all of these: compound 2.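

In this assay, putting 4-chlorophenyl in place of furan-2-yl on a double-bonded chain carbon bound to a double-bonded chain carbon gives a 1.2-fold lower number from compound 1 to compound 4 (0.06 log units; within the scatter). This first single-place comparison shows that the two aromatic rings cannot be told apart at this position, even though the six-membered ring brings more heavy atoms and no hydrogen-bond acceptor. Nothing measured here bears on why the two compounds give such similar numbers.

From the compounds shown here alone, it remains open whether an amine or a carboxylic acid in place of the chlorine of the 4-chlorophenyl group would shift the number beyond the scatter.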